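The source may report more compounds than this note shows. Statements on the series, on what has been measured and on what is new or still open speak of the compounds shown alone.

Compound 1, `O=C(Nc1cccc([N+](=O)[O-])c1)Nc1nc2ccc(F)cc2s1`: 0.83 ug/mL
Compound 2, `COc1ccc(C(=O)Nc2nc3cc(OC)ccc3s2)cc1`: > 10 ug/mL
Compound 3, `COc1ccccc1NC(=O)Nc1nc2ccc(F)cc2s1`: > 10 ug/mL

Of the three compounds measured in a functional assay on NUGC-3 cells (Homo sapiens) for antiproliferative activity, read by sulforhodamine B assay (a higher number here means a weaker inhibitor of growth, a lower number a stronger inhibitor of growth), only compound 1 returns a number. In this assay compound 2 gives > 10 ug/mL, which is a limit of the assay and not a measured number. Compound 3 likewise stops at a limit in this assay. Compound 2 therefore stands at the limit of > 10 ug/mL in this assay, at which 2 of the 3 values shown sit, and nothing separates it from compound 3 on the numbers shown.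

Compound 4, `COc1ccc2sc(NC(=O)c3ccc(C#N)cc3)nc2c1`, is not yet measured. It differs from compound 2 in one place: cyano in place of methoxy on an aromatic carbon. Within the data shown here, no step between measured compounds involves this exchange, so its size cannot be read from the data. Starting from a limit, the step from compound 2 to compound 4 is expected to be small, an at least 1.2-fold lower number from compound 2 to compound 4 (0.09 log units; that floor lies within the scatter), with a fair chance that the assay again reports only a limit. Compound 4 is expected to give about 8 ug/mL in this assay, within a range from 2 ug/mL to 25 ug/mL.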

Compound 4, concentration for 50% growth inhibition: > 10 ug/mL
Compound 4: a limit, no number (the forecaster's own chance of this, stated with the estimate: 55%); middle value at least 1.2-fold (0.09 log units) from the limit.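

Compound 4 gives > 10 ug/mL in this assay, which is a limit of the assay and not a number. Among these compounds, compound 2 also stops at a limit, so no step between compound 2 and compound 4 can be read. The compounds shown leave open whether cyano in place of methoxy on an aromatic carbon alters growth inhibition at all.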